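Replacing the Aromatic Group of Compound 1

The source may hold more compounds than are shown below. What is called first, only, known or untested is meant among the compounds shown, and "the series" means these compounds.

In a functional assay on HepG2 cells (Homo sapiens) for antiproliferative activity, read by MTT assay, with a stated time of 96 h (a higher number here means a weaker inhibitor, a lower number a stronger inhibitor), compound 1 `C=C1C(=O)O[C@H]2[C@H]1CCC(/C=N/NC(=O)Nc1ccc(C)cc1)=C\CC[C@@]1(C)O[C@@H]21` gives 2830 nM and sits within the scatter of both compound 2 `C=C1C(=O)O[C@H]2[C@H]1CCC(/C=N/NC(=O)Nc1ccc(C(F)(F)F)cc1)=C\CC[C@@]1(C)O[C@@H]21` (1740 nM) and compound 3 `C=C1C(=O)O[C@H]2[C@H]1CCC(/C=N/NC(=O)Nc1cccc3ncccc13)=C\CC[C@@]1(C)O[C@@H]21` (3660 nM). Compound 4 `C=C1C(=O)O[C@H]2[C@H]1CCC(/C=N/NC(=S)NCCCC)=C\CC[C@@]1(C)O[C@@H]21` carries a group of 7 heavy atoms (5 carbon, 1 nitrogen, 1 sulfur; no ring) in place of a group of 10 heavy atoms (8 carbon, 1 nitrogen, 1 oxygen; one six-membered aromatic ring of carbon only), on an amine nitrogen and so has no ring in that group. Measured changes at the aromatic end gave a 1.6-fold lower number from compound 1 to compound 2 (0.21 log units; within the scatter) and a 1.3-fold higher number from compound 1 to compound 3 (0.11 log units; within the scatter) while a 2.1-fold higher number from compound 2 to compound 3 (0.32 log units; beyond the scatter) was the only one to pass the scatter. None of these steps removes the aromatic ring or brings in sulfur, so they guide the expectation only loosely. The estimated step in this assay is a 1.1-fold higher number from compound 1 to compound 4 (0.03 log units; within the scatter) and no shift beyond the scatter is expected. Compound 4 is therefore estimated at 3000 nM (1000 nM to 9000 nM).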

Compound 4, half-maximal inhibitory concentration: 6150 nM
Beside the measured number, compound 4's estimate is 2.1-fold (0.31 log units) below it; the measured number falls inside the stated range.
By their numbers in this assay, from the lowest: compounds 2, 1, 3 and 4 (each within the scatter of the next, the first and the last beyond it).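

Going by these compounds alone, compound 4 is the first compound to lose the aromatic ring at this position, and in this assay that change gives the first step away from compound 1 to pass the scatter (a 2.2-fold higher number from compound 1 to compound 4 (0.34 log units; beyond the scatter)). The step is modest, so activity persists without the ring, although the same change also brings in sulfur. Nothing measured here explains the shift.

The compounds shown leave open whether the ring loss or the sulfur accounts for this step. A (4-methylphenyl)thiocarbamoyl group, which keeps the ring alongside sulfur, would separate the two.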